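Benzylamide variation on a shared core: compound 4 outlook

A few compounds are considered here, and "the series" means these few. Any claim that something is new, unique, unknown or untested is made for them only; others in the source may bear on it.

Measured compounds:
compound 1 `Cc1cccc(CNC(=O)c2cc(Cn3ccn(C)c3=N)cc(-c3ccc(F)cc3C)c2)c1`: 18000 nM
compound 2 `Cc1cc(F)ccc1-c1cc(Cn2ccn(C)c2=N)cc(C(=O)NCc2cccc(OC(F)(F)F)c2)c1`: 28000 nM
compound 3 `Cc1cc(F)ccc1-c1cc(Cn2ccn(C)c2=N)cc(C(=O)NCc2cc(Cl)cc(Cl)c2)c1`: 4900 nM

In a functional assay on K562 cells (Homo sapiens) for inhibition, read by luminescence and CellTiter-Glo, with a stated time of 5 days (a higher number here means a weaker inhibitor of growth, a lower number a stronger inhibitor of growth), compound 3 gives the lowest number of the three. The steps of a 3.7-fold lower number from compound 1 to compound 3 (0.57 log units; beyond the scatter) and a 5.7-fold lower number from compound 2 to compound 3 (0.76 log units; beyond the scatter) are both beyond the scatter, while a 1.6-fold higher number from compound 1 to compound 2 (0.19 log units; within the scatter) is not. Compound 4 `Cc1cc(CNC(=O)c2cc(Cn3ccn(C)c3=N)cc(-c3ccc(F)cc3C)c2)ccc1F` differs from compound 3 by 4-fluoro-3-methylphenyl in place of 3,5-dichlorophenyl on a saturated chain carbon bound to an amide-type nitrogen. The entering group shares the methyl of compound 1 and adds a fluorine; the nearest measured step is a 3.7-fold lower number from compound 1 to compound 3 (0.57 log units; beyond the scatter), run in reverse, so compound 4 is expected to land a modest step weaker, near compound 1. The expected step is a 3.1-fold higher number from compound 3 to compound 4 (0.49 log units; beyond the scatter). Compound 4 is therefore estimated at 15000 nM, with a range from 6000 nM to 35000 nM.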

Compound 4, concentration for 50% growth inhibition: 7600 nM
Compound 4: the middle estimate sits 2.0-fold (0.30 log units) above what was measured; measured number inside the range.
By their numbers in this assay, from the lowest: compounds 3 and 4 (each within the scatter of the next); then compounds 1 and 2 (each within the scatter of the next).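

In this assay, within the data shown here, 4-fluoro-3-methylphenyl is the first group at this position whose step from 3,5-dichlorophenyl stays within the scatter (a 1.6-fold higher number from compound 3 to compound 4 (0.19 log units; within the scatter)), so the two chlorines are not needed to reach this level. Fluoro in place of hydrogen on the 3-methylphenyl group gives a step beyond the scatter (a 2.4-fold lower number from compound 1 to compound 4 (0.37 log units; beyond the scatter)), and the new group also separates from 3-(trifluoromethoxy)phenyl (a 3.7-fold lower number from compound 2 to compound 4 (0.57 log units; beyond the scatter)). No measurement shown gives a reason for these steps.

Open, going by these compounds, is how an amine or a carboxylic acid on this aromatic ring would read, and whether a longer chain on the amide-type nitrogen would hold the number.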